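The source may report more compounds than this note shows. Statements on the series, on what has been measured and on what is new or still open speak of the compounds shown alone.

Measured in an ADME assay on Vero cells (Chlorocebus sabaeus) for cytotoxicity, read by MTT assay, with a stated time of 72 h; a lower number here means that less compound is tolerated, a higher number that more compound is tolerated: compound 1 `CCCCCCCCCCCCC#Cc1cn(C2C=CC(O)C2)c(=O)[nH]c1=O` gives > 100 ug/mL; > 100 ug/mL; 125 ug/mL (3 entries). In this assay compound 2 `CCCCCCCCCCC#Cc1cn(C2C=CC(O)C2)c(=O)[nH]c1=O` gives > 125 ug/mL. In this assay compound 3 `Cc1cc(=O)[nH]c(=O)n1C1C=CC(O)C1` gives > 200 ug/mL.

For compound 1, two of the three entries are limits of the assay rather than numbers, as seen in the several entries of compound 1 in this assay, > 100 ug/mL; > 100 ug/mL; 125 ug/mL (3 entries). The value of compound 2 is a limit of the assay. The value of compound 3 is likewise a limit of the assay and not a number, as the limit of > 200 ug/mL in this assay, at which 1 of the 3 values shown sits, shows. Compound 3 therefore stands where no single number is known, and the same holds for compound 2 and for part of what is known of compound 1.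

Compound 4 `O=c1ccn(C2C=CC(O)C2)c(=O)[nH]1` differs from compound 3 by hydrogen in place of methyl on an aromatic carbon. For the measured compounds named here, no measured step of this kind exists here. In this assay the step of a number no higher from compound 3 to compound 4 (the limit leaves the size open) is expected to be none beyond the scatter. Compound 4 is therefore expected to give about 200 ug/mL, between 100 ug/mL and 400 ug/mL, most likely again as a limit.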

Compound 4, half-maximal cytotoxic concentration: > 200 ug/mL
Compound 4: no number, only a limit; the forecaster's own chance of this, stated with the estimate: 80%; the middle value sits exactly at the limit.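

Compound 3 and compound 4 each give only a limit of the assay, so the step from methyl to hydrogen cannot be read. The compounds shown leave open whether, and at what concentration, either compound harms the cells.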